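The compounds below may be only part of what the source reports. "The series", "measured", "known", "first", "only" and "open" are said of these compounds alone.

Working notes on the series. In an assay on microsomes from brain for inhibition of Fatty-acid amide hydrolase 1 (Rattus norvegicus), read by fluorescence and HPLC, with a stated time of 60 min (a higher number here means a weaker inhibitor, a lower number a stronger inhibitor), compound 1 `CC(Oc1ccc(Oc2ccc(Cl)cc2)cc1)C(=O)Cn1nnc(-c2ccccc2)n1` gives 51 nM, compound 2 `CC(Oc1ccc(Oc2ccc(C(F)(F)F)cc2)cc1)C(=O)Cn1nnc(-c2ccccc2)n1` gives 160 nM and compound 3 `CC(Oc1ccc(-c2ccccc2)cc1)C(=O)Cn1nnc(-c2ccccc2)n1` gives 15 nM, the lowest number of the three. Every step measured so far sits on the aryl carried by the ether: a 3.1-fold higher number from compound 1 to compound 2 (0.50 log units; beyond the scatter), a 3.4-fold lower number from compound 1 to compound 3 (0.53 log units; beyond the scatter) and an 11-fold lower number from compound 2 to compound 3 (1.03 log units; beyond the scatter). Compound 4 `CC(Oc1ccc(-c2ccccc2)cc1)C(=O)Cn1nnc(-c2ccc(Cl)cc2)n1` differs from compound 3 elsewhere, at the phenyl on the far side of the shared core: chloro in place of hydrogen on an aromatic carbon. For the measured compounds named here, no measured step touches that phenyl, so there is no step here to scale a change from; in this assay a step within the scatter, no change at the digits printed from compound 3 to compound 4 (within the scatter), is expected. Compound 4 is therefore estimated at 15 nM, with a range of 6 nM to 40 nM.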

Compound 4, half-maximal inhibitory concentration: 25 nM
Beside the measured number, compound 4's estimate is 1.7-fold (0.22 log units) below it, and the stated range covers the measured number.
By their numbers in this assay, from the lowest: compounds 3 and 4 (each within the scatter of the next); then compound 1; then compound 2.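

For the compounds shown here, this is the first reading at the phenyl on the far side of the shared core: in this assay, chloro in place of hydrogen on an aromatic carbon, para to a large group, gives a 1.7-fold higher number from compound 3 to compound 4 (0.22 log units; within the scatter). A single chlorine at this position therefore leaves the number within the scatter, unlike the steps on the aryl carried by the ether, which all lie beyond it. Nothing available offers an explanation for this result.

Going by these compounds, whether a larger or different group here, such as an amine or a carboxylic acid, would also leave the number unmoved stays open. So does whether the same chloro step holds with the 4-chlorophenoxy of compound 1 on the other side.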